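The source may hold more compounds than are shown below. What is called first, only, known or untested is meant among the compounds shown, and "the series" means these compounds.

Measured compounds and values in a functional assay on HEK293 cells for positive allosteric modulation of metabotropic glutamate receptor 5 (Rattus norvegicus), read by fluorescence and calcium flux; on this read-out higher numbers stand for larger maximal responses and lower numbers for smaller maximal responses:
compound 1 `C[C@@H](NC(=O)c1ccc(C#Cc2ccccc2F)cn1)C(C)(C)O`: 60%
compound 2 `Cc1ccccc1C#Cc1ccc(C(=O)N[C@H](C)C(C)(C)O)nc1`: 59.9%
compound 3 `C[C@@H](NC(=O)c1ccc(C#Cc2ccc(F)cn2)cn1)C(C)(C)O`: 64.6%

Compound 3 carries the top number of the three in this assay, but both steps to it lie within the scatter: a number 4.6 percentage points higher from compound 1 to compound 3 (within the scatter) and a number 4.7 percentage points higher from compound 2 to compound 3 (within the scatter). Among the measured compounds shown here, the step of a number 0.1 percentage points lower from compound 1 to compound 2 (within the scatter) is likewise within the scatter, so nothing measured so far moves the maximal response beyond noise.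

Compound 4 `C[C@@H](NC(=O)c1ccc(C#Cc2ncccc2F)cn1)C(C)(C)O` differs from compound 3 by 3-fluoropyridin-2-yl in place of 5-fluoropyridin-2-yl on a triple-bonded carbon. For the measured compounds named here, the two earlier replacements on the triple-bonded carbon, a number 4.6 percentage points higher from compound 1 to compound 3 (within the scatter) and a number 4.7 percentage points higher from compound 2 to compound 3 (within the scatter), are the steps that bear on this change, and both were within the scatter. No step beyond the scatter is therefore expected: a number 2.6 percentage points lower from compound 3 to compound 4 (within the scatter). Compound 4 is estimated at 62%, with a range from 52% to 72%.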

Compound 4, largest response reached (reported as efficacy), in percent of the reference or control that the assay uses: 60.6%
Beside the measured number, compound 4's estimate is 1.4 percentage points above it, within the range that was stated.
By their numbers in this assay, from the lowest: compounds 2, 1, 4 and 3 (each within the scatter of the next).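

In this assay, the same atoms rearranged, 3-fluoropyridin-2-yl in place of 5-fluoropyridin-2-yl on the triple-bonded carbon, give a number 4 percentage points lower from compound 3 to compound 4 (within the scatter), so the two fluoropyridine isomers are not told apart here. Against the two substituted phenyl groups, the steps are a number 0.7 percentage points higher from compound 2 to compound 4 (within the scatter) and a number 0.6 percentage points higher from compound 1 to compound 4 (within the scatter), leaving all four groups on this carbon within the scatter of one another. Nothing available explains these numbers.

Open, going by these compounds, is whether a non-aromatic group on this carbon, such as cyclohexyl or a longer alkyl chain, moves the maximal response beyond the scatter. Also open, on these data alone, is the effect of an amine or a carboxylic acid in place of the hydroxyl on the amide side chain.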